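This account rests on a few compounds, and the source may have more. Where it says the series, first, only, none or still open, it means among the compounds named here.

Compound 1 `CCN(CC)S(=O)(=O)c1ccc(S(=O)(=O)N2CCC[C@@H](C(=O)N[C@H]3CC[C@H](OC)CC3)C2)cc1`, compound 2 `CC(C)S(=O)(=O)c1ccc(S(=O)(=O)N2CCC[C@@H](C(=O)N3CCC(F)(F)CC3)C2)cc1` and compound 3 `O=C([C@@H]1CCCN(S(=O)(=O)c2ccc(S(=O)(=O)C3CC3)cc2)C1)N1CCC(F)(F)CC1` were measured in a functional assay on BXPC-3 cells (Homo sapiens) for inhibition, read by MTT assay, with a stated time of 7 days; a lower number here means a stronger inhibitor, a higher number a weaker inhibitor: compound 1 gives 2000 nM, compound 2 gives 50 nM, and compound 3 gives 129 nM.

Compound 1 stands highest of the three in this assay, and its gaps to compound 3 and to compound 2 both lie beyond the scatter, so it is the weakest inhibitor of this set. For the measured compounds named here, the only step between compounds that differ in a single place is a 2.6-fold higher number from compound 2 to compound 3 (0.41 log units; beyond the scatter), and it concerns the sulfonyl group, not the amide side of the shared core.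

Compound 4 `CCN(CC)S(=O)(=O)c1ccc(S(=O)(=O)N2CCC[C@@H](C(=O)N[C@H]3CCOC3)C2)cc1` differs from compound 1 by oxolan-3-yl in place of 4-methoxycyclohexyl on an amide-type nitrogen. Going by the values given here, none of the measured steps touches this position, and the values of compounds 2 and 3 involve a different amide group together with a different sulfonyl group, so they do not isolate this change. Compound 4 is therefore expected to stay near compound 1, with a step of a 1.3-fold higher number from compound 1 to compound 4 (0.10 log units; within the scatter) that is not expected to exceed the scatter. The estimate for compound 4 in this assay is 2500 nM, with a range from 700 nM to 9000 nM.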

Compound 4, half-maximal inhibitory concentration: 5270 nM
The estimate for compound 4 lay 2.1-fold (0.32 log units) below the measured number, within the range that was stated.
By their numbers in this assay, from the lowest: compound 2; then compound 3; then compound 1; then compound 4.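

In this assay, the amide side of the shared core now has a step of its own: oxolan-3-yl in place of 4-methoxycyclohexyl on the amide-type nitrogen gives a 2.6-fold higher number from compound 1 to compound 4 (0.42 log units; beyond the scatter) and so moves the number beyond the scatter, showing that this position is not indifferent to the group it carries. The two groups have the same counts of hydrogen-bond donors and acceptors and neither has a net charge, so the step goes with a difference in the ring and in the size of the group, not with a difference in those counts. Nothing given here bears on the reason for the step.

The compounds shown leave open whether a plain cyclohexyl or an oxan-4-yl group on the same nitrogen would stand nearer compound 1 or compound 4. They also leave open whether the same exchange would give a similar step with the isopropyl sulfonyl group of compound 2 in place of the diethylsulfamoyl group.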